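This account rests on a few compounds, and the source may have more. Where it says the series, first, only, none or still open, it means among the compounds named here.

Three compounds share one core and differ only in the group attached to one aromatic carbon of that core. In a functional assay on MDA-MB-231 cells (Homo sapiens) for cytotoxicity, read by MTT assay, with a stated time of 72 h (on this read-out lower numbers stand for stronger inhibition and higher numbers for weaker inhibition), compound 1 `O=C(Nc1ccc(-n2ncc3c(C(F)(F)F)cccc32)cc1)Nc1ccc(Cl)c(C(F)(F)F)c1` gives 2000 nM, compound 2 `O=C(Nc1ccc(-n2ncc3c(Cl)cccc32)cc1)Nc1ccc(Cl)c(C(F)(F)F)c1` gives 1600 nM and compound 3 `Cc1cccc2c1cnn2-c1ccc(NC(=O)Nc2ccc(Cl)c(C(F)(F)F)c2)cc1` gives 2300 nM. Compound 3 stands at the highest of the three numbers, though every step to it is small: a 1.2-fold higher number from compound 1 to compound 3 (0.06 log units; within the scatter) and a 1.4-fold higher number from compound 2 to compound 3 (0.16 log units; within the scatter), while a 1.3-fold lower number from compound 1 to compound 2 (0.10 log units; within the scatter). Exchanging the group on this carbon has so far left the read-out essentially where it was.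

Compound 4 `COc1cccc2c1cnn2-c1ccc(NC(=O)Nc2ccc(Cl)c(C(F)(F)F)c2)cc1` brings the next exchange at the same place: methoxy in place of methyl on an aromatic carbon. All three measured steps bear on it, since each one swaps the group on this carbon, and none moved the number beyond the scatter. The expected step in this assay from compound 3 to compound 4 is therefore no change at the digits printed from compound 3 to compound 4 (within the scatter), that is, no movement beyond the scatter in either direction. Compound 4 is estimated at 2300 nM, with a range from 1100 nM to 4800 nM.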

Compound 4, half-maximal inhibitory concentration: 1200 nM
For compound 4 the middle estimate is 1.9-fold (0.28 log units) above the measured one; the range from low to high includes it.
By their numbers in this assay, from the lowest: compounds 4, 2, 1 and 3 (each within the scatter of the next).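

In this assay, methoxy differs from the methyl it replaces by carrying an oxygen and counting one hydrogen-bond acceptor, yet the step stays within the scatter: a 1.9-fold lower number from compound 3 to compound 4 (0.28 log units; within the scatter). The comparisons with the other two groups read the same way, with a 1.3-fold lower number from compound 2 to compound 4 (0.12 log units; within the scatter) and a 1.7-fold lower number from compound 1 to compound 4 (0.22 log units; within the scatter), so all four groups on this aromatic carbon now lie within the scatter of one another, and adding an oxygen here has not moved the read-out beyond it. Nothing available offers an explanation for this flat picture.

Going by these compounds, whether an amine, a carboxylic acid or a longer chain on this carbon would carry the number beyond the scatter remains open. So does whether the same flatness would hold if another part of the shared core were changed.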